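Cyclohexyl in Place of Butyl: Expected Adenosine Receptor Affinity

The compounds below may be only part of what the source reports. "The series", "measured", "known", "first", "only" and "open" are said of these compounds alone.

Measured compounds:
Compound 1, `CNC(=O)OC[C@H]1OC(n2cnc3c(NC4CCOC4)nc(Cl)nc32)[C@H](O)[C@@H]1O`: in an assay on DDT1 cells (Cricetulus griseus) for binding affinity to adenosine receptor A1 (Homo sapiens), read by radioligand binding (on this read-out lower numbers stand for stronger inhibition and higher numbers for weaker inhibition), compound 1 gives 96 nM.
Compound 2, `C/N=C(\S)OC[C@H]1OC(n2cnc3c(NC4CCOC4)nc(Cl)nc32)[C@H](O)[C@@H]1O`: compound 2 gives 71 nM.
Compound 3, `CCCC/N=C(\S)OC[C@H]1OC(n2cnc3c(NC4CCOC4)ncnc32)[C@H](O)[C@@H]1O`: compound 3 gives 157 nM.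

Compound 3 gives the highest of the three numbers. Its gap to compound 1 is within the scatter, so the two cannot be told apart; its gap to compound 2 lies beyond the scatter. Among the measured compounds shown here, the one step measured between neighbours, a 1.4-fold lower number from compound 1 to compound 2 (0.13 log units; within the scatter), swaps an oxygen-containing group for a sulfur-containing group and does not touch the part changed here.

Compound 4, `O[C@@H]1[C@@H](CO/C(S)=N/C2CCCCC2)OC(n2cnc3c(NC4CCOC4)ncnc32)[C@@H]1O`, arises from compound 3 by cyclohexyl in place of butyl on a double-bonded nitrogen. For the measured compounds named here, no measured pair shows what replacing a chain by a ring at this nitrogen does, and the only measured step was itself within the scatter. The expectation is therefore a step of a 1.0-fold lower number from compound 3 to compound 4 (0.02 log units; within the scatter), that is none beyond the scatter. Compound 4 is estimated at 150 nM, with a range from 50 nM to 450 nM.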

Compound 4, inhibition constant: 253 nM
Compound 4: the middle estimate sits 1.7-fold (0.23 log units) below what was measured; low and high end bracket the measured number.
By their numbers in this assay, from the lowest: compounds 2, 1, 3 and 4 (each within the scatter of the next, the first and the last beyond it).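

In this assay the swap of butyl for cyclohexyl on a double-bonded nitrogen gives a 1.6-fold higher number from compound 3 to compound 4 (0.21 log units; within the scatter) so the two compounds cannot be told apart. Among the compounds shown here, this is the first measured pair that changes this group, and it shows that, in this one pair, an open chain and a six-membered ring of carbon only give readings that cannot be separated. No measurement shown here offers an explanation for this result.

Only butyl and cyclohexyl can be compared directly at this nitrogen on the same core, so one pair cannot show how a smaller ring such as cyclopentyl, an aromatic phenyl ring or a chain ending in an amine would read. On these data alone, whether cyclohexyl would read the same on the chlorine-bearing core of compound 2 also stays open.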